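Solubility of an aryl ether series: from tolyl to dihydrobenzofuranyl

A few compounds are considered here, and "the series" means these few. Any claim that something is new, unique, unknown or untested is made for them only; others in the source may bear on it.

Measured so far:
Compound 1 `Cn1c(COc2cccc(C(=O)O)c2)nc2cnc(Oc3ccc(Cl)c(F)c3)cc21`: in a physicochemical assay for solubility, read by HPLC, measured as thermodynamic solubility, with a stated time of 4 h, at pH 6.8 (on this read-out higher numbers stand for higher solubility and lower numbers for lower solubility), compound 1 gives 11 ug/mL.
Compound 2 `Cc1ccc(Oc2cc3c(cn2)nc(COc2cccc(C(=O)O)c2)n3C)cc1`: in this assay compound 2 gives 360 ug/mL.

Among the compounds with values here, compound 2 stands at the higher of the two numbers measured in this assay; its nearest neighbour, compound 1, lies well below it, and the single step between them, a 33-fold higher number from compound 1 to compound 2 (1.51 log units; beyond the scatter), is a large one that exchanges a 4-methylphenyl for a 4-chloro-3-fluorophenyl on an oxygen on an aromatic ring.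

Compound 3 `Cn1c(COc2cccc(C(=O)O)c2)nc2cnc(Oc3ccc4c(c3)OCC4)cc21` has not yet been measured. It differs from compound 2 in one place: a group of 9 heavy atoms (8 carbon, 1 oxygen; one five-membered non-aromatic ring with 1 hetero atom, one six-membered aromatic ring of carbon only) in place of a group of 7 heavy atoms (7 carbon; one six-membered aromatic ring of carbon only), on an oxygen on an aromatic ring. Within the data shown here, no measured step exchanges an aromatic ring for a group containing an additional non-aromatic ring with an oxygen, so the step from compound 1 to compound 2 bears on it only loosely, as an indication of how strongly this position can move the read-out. A moderate drop, beyond the scatter but far smaller than the step from compound 1 to compound 2, is expected, a 2.4-fold lower number from compound 2 to compound 3 (0.38 log units; beyond the scatter). Compound 3 is therefore estimated at 150 ug/mL, with a range from 40 ug/mL to 500 ug/mL.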

Compound 3, solubility: 79 ug/mL
Estimate against measurement, compound 3: 1.9-fold (0.28 log units) above; the range from low to high includes it.
By their numbers in this assay, from the lowest: compound 1; then compound 3; then compound 2.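

In this assay, this position on the oxygen now shows more than one large jump: replacing the 4-chloro-3-fluorophenyl with the group containing the five-membered non-aromatic ring also gives a rise beyond the scatter, a 7.2-fold higher number from compound 1 to compound 3 (0.86 log units; beyond the scatter), although that rise is smaller than a 33-fold higher number from compound 1 to compound 2 (1.51 log units; beyond the scatter). The comparison with 4-methylphenyl, a 4.6-fold lower number from compound 2 to compound 3 (0.66 log units; beyond the scatter), places the new group between the other two, so the group with one hydrogen-bond acceptor does not give the highest number among these three. Nothing available explains why the three groups fall in this order.

The compounds shown do not separate the contributions of the chlorine and the fluorine, so a 4-chlorophenyl or a 3-fluorophenyl on the same oxygen would be needed to show whether one halogen alone gives a number as low as the pair does. As far as these compounds go, it also remains open where a group with an amine on its ring, or a group with no aromatic ring, such as cyclohexyl, would fall in this order.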